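Fluorophenyl to Trimethoxyphenyl: an Expected Potency Shift

The source may hold more compounds than are shown below. What is called first, only, known or untested is meant among the compounds shown, and "the series" means these compounds.

Of the compounds shown here, three have so far been tested in a functional assay on ECa-109 cells (Homo sapiens) for inhibition, read by MTT assay, with a stated time of 72 h; on this read-out lower numbers stand for stronger inhibition and higher numbers for weaker inhibition. For the measured compounds named here, compound 2, `O=C(OCc1ccccc1)N1CCN(C(=S)SCc2cn(Cc3ccc(F)cc3)nn2)CC1`, is the only one that returns a number: in this assay compound 2 gives 32000 nM. Compound 1, `CC(C)(C)OC(=O)N1CCN(C(=S)SCc2cn(-c3ccccc3F)nn2)CC1`, reaches only a limit of the assay, > 128000 nM. Compound 3, `S=C(SCc1cn(Cc2ccccc2Cl)nn1)N1CCNCC1`, likewise reaches only a limit, > 128000 nM. The remaining two values therefore sit at the limit of > 128000 nM in this assay, at which 2 of the 3 values shown sit. Going by the values given here, no two of these three compounds differ in just one place, so no single structural step has yet been measured, and compound 2 simply stands alone as the sole numeric result.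

Compound 4, `COc1cc(Cn2cc(CSC(=S)N3CCN(C(=O)OCc4ccccc4)CC3)nn2)cc(OC)c1OC`, is built from compound 2 by one change: 3,4,5-trimethoxyphenyl in place of 4-fluorophenyl on a saturated chain carbon bound to an aromatic nitrogen. Among the compounds with values here, no measured step guides this change, so its size and direction in this assay are open. The shift is expected to be modest, a 1.6-fold lower number from compound 2 to compound 4 (0.20 log units; within the scatter), with a small gain about as likely as no change beyond the usual scatter. Compound 4 is accordingly estimated at 20000 nM, within a range from 5000 nM to 80000 nM.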

Compound 4, half-maximal inhibitory concentration: > 128000 nM
Compound 4: only a limit was reported; the forecaster's own chance of this, stated with the estimate: 15%; middle value at least 6.4-fold (0.80 log units) from the limit.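

In this assay, for the compounds shown here, this is the first measured step at this position: placing 3,4,5-trimethoxyphenyl in place of 4-fluorophenyl on a saturated chain carbon bound to an aromatic nitrogen gives an at least 4.0-fold higher number from compound 2 to compound 4 (0.60 log units; beyond the scatter). The change therefore runs towards weaker inhibition, beyond the scatter, and the entering group, with 12 heavy atoms against 7, does not keep the measurable inhibition seen before the change. The true size of the step stays unknown, since compound 4 reaches only a limit, one that most of the set shares: the limit of > 128000 nM in this assay, at which 3 of the 4 values shown sit.

A phenyl ring with a single methoxy group, or with an amine or a carboxylic acid, would help show which part of the change matters. Also open, on these data alone, is whether any group here can improve on compound 2, at 32000 nM.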